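This account rests on a few compounds, and the source may have more. Where it says the series, first, only, none or still open, it means among the compounds named here.

Of the compounds shown here, three have been measured in a functional assay on cells (Panel NCI-60 (60 carcinoma cell lines), Homo sapiens); a lower number here means that less compound is tolerated, a higher number that more compound is tolerated.
Compound 1, `O=C1C=CC(O)(c2cc3ccc(F)cc3n2S(=O)(=O)c2ccccc2)C=C1`, gives 2240 nM.
Compound 2, `Cc1ccc(S(=O)(=O)n2c(C3(O)C=CC(=O)C=C3)cc3ccccc32)cc1`, gives 7240 nM.
Compound 3, `COc1ccc2c(c1)cc(C1(O)C=CC(=O)C=C1)n2S(=O)(=O)c1ccccc1`, gives 6170 nM.

Compound 2 has the highest of these three numbers. Its gap to compound 3 is within the usual scatter, so those two cannot be ranked against each other. Its gap to compound 1 is larger and lies beyond the scatter, so compound 1 is the one of which less is tolerated in this assay. Compound 4, `O=C1C=CC(O)(c2cc3ccccc3n2S(=O)(=O)c2ccc(F)cc2)C=C1`, has not yet been measured. It differs from compound 2 in one place: fluoro in place of methyl on an aromatic carbon. For the measured compounds named here, no measured pair shows this exact change, so its effect cannot be read from the data. The expectation is a modest step in this assay of a 1.4-fold lower number from compound 2 to compound 4 (0.16 log units; within the scatter), toward a somewhat lower number. Compound 4 is expected near 5000 nM, most likely between 2500 nM and 10000 nM.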

Compound 4, concentration lethal to 50% of the cells: 7760 nM
Compound 4: the middle estimate sits 1.6-fold (0.19 log units) below what was measured; the range from low to high includes it.
By their numbers in this assay, from the lowest: compound 1; then compounds 3, 2 and 4 (each within the scatter of the next).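

In this assay the swap of 4-methylphenyl for 4-fluorophenyl gives a 1.1-fold higher number from compound 2 to compound 4 (0.03 log units; within the scatter) and so lies within the scatter. For the compounds shown here, this is the first direct reading at this position, and it shows that compound 2 and compound 4 cannot be told apart, so fluoro and methyl on this aromatic carbon are interchangeable in this read-out, at least in this one pair. Nothing measured here explains the result. This single pair cannot say whether the same swap would behave alike elsewhere on the shared core. On these data alone, what an amine or a carboxylic acid on this same carbon would give also remains open.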